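The source may hold more compounds than are shown below. What is called first, only, known or untested is meant among the compounds shown, and "the series" means these compounds.

Of the compounds shown here, three of one series have been tested in an ADME assay on Vero cells (Chlorocebus sabaeus) for cytotoxicity, read by MTT assay, with a stated time of 72 h; on this read-out higher numbers stand for lower toxicity in this test and lower numbers for higher toxicity in this test. Compound 1, `COC(=O)c1cc(-c2cccc(NC(=O)c3ccc(/C=C/C(=O)c4cccc(Cl)c4)cc3)c2)on1`, carries a chloro group on the outer aromatic ring, and in this assay compound 1 gives only a limit, > 2.5 ug/mL. Compound 2, `COC(=O)c1cc(-c2cccc(NC(=O)c3ccc(/C=C/C(=O)c4cccc([N+](=O)[O-])c4)cc3)c2)on1`, carries a nitro group in place of that chloro group, and in this assay compound 2 also gives only a limit, > 40 ug/mL. The step from compound 1 to compound 2, a step that the two limits leave unreadable from compound 1 to compound 2, is a change whose size cannot be read, because both ends are limits, as the limit of > 2.5 ug/mL in this assay, at which 1 of the 3 values shown sits, and the limit of > 40 ug/mL in this assay, at which 1 of the 3 values shown sits, show. Compound 3, `COC(=O)c1cc(-c2cccc(NC(=O)c3ccc(/C=C/C(=O)c4ccccc4O)cc3)c2)on1`, has in this assay the entry "not determined" (no result reported). So compound 2 stands at the more favourable of the two limits, with no number beside it.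

Compound 4, `COC(=O)c1cc(-c2cccc(NC(=O)c3ccc(/C=C/C(=O)c4ccccc4C)cc3)c2)on1`, differs from compound 2 in one place: 2-methylphenyl in place of 3-nitrophenyl on a carbonyl carbon. No measured step bears on this change with a readable size, since the only step shown is unreadable. The change from compound 2 to compound 4 is therefore expected to be a number no higher from compound 2 to compound 4 (the limit leaves the size open), with wide uncertainty in either direction. For compound 4 the estimate in this assay is 40 ug/mL, expected to fall between 10 ug/mL and 100 ug/mL, and the outcome may again be only a limit.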

Compound 4, half-maximal cytotoxic concentration: > 25 ug/mL
Compound 4 was reported as a limit; the forecaster's own chance of this, stated with the estimate: 60%; the middle value does not contradict the limit.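

In this assay compound 4 gives only a limit, > 25 ug/mL. Compound 1 and compound 2 also give only limits, so the steps from compound 2 to compound 4 and from compound 1 to compound 4 cannot be read as sizes. The compounds shown leave open whether exchanging these groups on the carbonyl carbon changes toxicity at all.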